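From trifluoromethoxy to fluoro in a cytotoxicity assay

The source may report more compounds than this note shows. Statements on the series, on what has been measured and on what is new or still open speak of the compounds shown alone.

Measured in an ADME assay on HEK293 cells (Homo sapiens) for cytotoxicity, with a stated time of 72 h (a higher number here means that more compound is needed for the effect, a lower number that less compound is needed), so far:
- compound 1 `C=C[C@@](C)(/C=C/c1ccc(Nc2ccc(OC)cc2)cc1)CCC=C(C)C` gives > 36600 nM as a limit of the assay
- compound 2 `C=C[C@@](C)(/C=C/c1ccc(Nc2ccc(OC(F)(F)F)cc2)cc1)CCC=C(C)C` gives > 36600 nM as a limit of the assay

In this assay compound 2 stands at > 36600 nM as a limit, not as a number. Among the measured compounds shown here, the only other value shown is a limit too. Compound 3 `C=C[C@@](C)(/C=C/c1ccc(Nc2ccc(F)cc2)cc1)CCC=C(C)C` has not yet been measured. It departs from compound 2 in one place: fluoro in place of trifluoromethoxy on an aromatic carbon. Fluoro thus takes the place of trifluoromethoxy on an aromatic carbon.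

For the measured compounds named here, only one measured step bears on this change. It is a step that the two limits leave unreadable from compound 1 to compound 2, with trifluoromethyl in place of methyl on an oxygen on an aromatic ring. That step offers no size to carry over, and the record consists of the limit of > 36600 nM in this assay, at which 2 of the 2 values shown sit, alone. No step beyond the scatter is therefore expected, and no direction can be given. The expected change is a number no higher from compound 2 to compound 3 (the limit leaves the size open) as an estimate. For compound 3 the estimated value is 36600 nM, with an expected range from 18000 nM to 73000 nM and a report as a limit being the likeliest outcome.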

Compound 3, half-maximal effective concentration: > 36600 nM
Compound 3: no number, only a limit; the forecaster's own chance of this, stated with the estimate: 75%; the middle value lies on the limit itself.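

Among the compounds shown here, no step between compound 1, compound 2 and compound 3 can be read in this assay, where each of the three is reported only as a limit: the limit of > 36600 nM in this assay, at which 3 of the 3 values shown sit.

The compounds shown leave open what concentration any of them needs for the effect, and whether exchanging methoxy, trifluoromethoxy and fluoro changes it at all.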